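Methyl in place of trifluoromethyl: compound 2 to compound 4

The compounds below may be only part of what the source reports. "The series", "measured", "known", "first", "only" and "open" are said of these compounds alone.

Three compounds of the series have numbers in a functional assay on CHO cells with metabotropic glutamate receptor 2 (Homo sapiens) as the target, read by GTPgammaS binding; on this read-out lower numbers stand for smaller maximal responses and higher numbers for larger maximal responses. Compound 1, `CCCCn1ccc(N2CCN(c3nc(C)cc(C)n3)CC2)c(C#N)c1=O`, gives 235%. Compound 2, `Cc1cc(C)nc(N2CCN(c3ccn4c(CC(F)(F)F)cnc4c3C#N)CC2)n1`, gives 128%. Compound 3, `N#Cc1c(-c2ccc(N3CCCCC3)cc2)ccn2c(CC(F)(F)F)cnc12`, gives 123%. Among these three, compound 2 stands second highest. Its number and that of compound 3 lie within the scatter of each other, so nothing separates the two; compound 1 stands beyond the scatter above compound 2.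

Compound 4, `CCc1cnc2c(C#N)c(N3CCN(c4nc(C)cc(C)n4)CC3)ccn12`, has not been measured. It differs from compound 2 in a single place: methyl in place of trifluoromethyl on a saturated chain carbon bound to an aromatic carbon. Cut one bond further out, the same change reads 2,2,2-trifluoroethyl to ethyl. Going by the values given here, no two measured compounds differ in only one place, so no measured step of this assay guides this change; compounds 1, 2 and 3 differ from one another in more than one place each.

With nothing measured in that direction, the step of a number 3 percentage points lower from compound 2 to compound 4 (within the scatter) is expected to be small, with no direction beyond the scatter. Compound 4 is therefore expected to give about 125% in this assay, estimated between 95% and 160%.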

Compound 4, largest response reached (Emax), in percent of the reference or control that the assay uses: 142%
For compound 4 the middle estimate is 17 percentage points below the measured one; measured number inside the range.
By their numbers in this assay, from the lowest: compounds 3 and 2 (each within the scatter of the next); then compound 4; then compound 1.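

In this assay the series now has its first step between compounds that differ in one place: a number 14 percentage points higher from compound 2 to compound 4 (beyond the scatter) with methyl in place of trifluoromethyl on a saturated chain carbon bound to an aromatic carbon. The maximal response at this position therefore responds to this change, and the step lies beyond the scatter, although it is modest. The three fluorine atoms of the 2,2,2-trifluoroethyl group are not needed for a response of this size, as the ethyl group of compound 4 shows, but nothing at hand explains why the number moves in this direction.

As far as these compounds go, this single step gives no trend along the chain, so it remains open whether a longer chain such as propyl, or a 2-hydroxyethyl or 2-aminoethyl group, would carry the number further or bring it back. From the compounds shown here alone, it also remains open whether the same change would give a step of similar size and direction in compound 3, which carries the same 2,2,2-trifluoroethyl group with a different remainder of the molecule.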